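This account rests on a few compounds, and the source may have more. Where it says the series, first, only, none or still open, it means among the compounds named here.

Of the compounds shown here, three have been measured in an assay on HEK293 cells for inhibition of transient receptor potential cation channel subfamily M member 8 (Homo sapiens), read by FLIPR, with stated times of 5 min and 3 min; on this read-out lower numbers stand for stronger inhibition and higher numbers for weaker inhibition. Compound 1 `CCOC(=O)c1sc(-c2ccc(C)cc2)nc1O` gives 160 nM in this assay. Compound 2 `CCOC(=O)Cc1sc(-c2ccccc2)nc1O` gives 950 nM, and compound 3 `CCn1nnc(-c2sc(-c3cnccn3)nc2O)n1` gives 1890 nM. Among these three, compound 2 holds the second highest number; its nearest neighbour is compound 3, whose number lies within the usual scatter of it, while compound 1 sits furthest away, with a lower number that lies beyond the scatter. The unmeasured compound 4 `CCN(C)C(=O)c1sc(-c2ccccc2)nc1O` differs from compound 2 in one place: ethyl(methyl)carbamoyl in place of (ethoxycarbonyl)methyl on an aromatic carbon. Going by the values given here, no step between two measured compounds repeats this change, so its size cannot be read from the measured pairs. The account expects for the step from compound 2 to compound 4 a modest move toward a lower number, a 1.7-fold lower number from compound 2 to compound 4 (0.24 log units; within the scatter), one that may well stay within the scatter. Compound 4 is therefore estimated at 550 nM, with a range from 150 nM to 2000 nM.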

Compound 4, half-maximal inhibitory concentration: 6400 nM
Compound 4: the middle estimate sits 12-fold (1.07 log units) below what was measured; the whole stated range lies below it.
By their numbers in this assay, from the lowest: compound 1; then compounds 2 and 3 (each within the scatter of the next); then compound 4.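

In this assay, the aromatic carbon next to the ring sulfur and next to the ring atom that bears a hydroxy group proves sensitive to the group it carries: ethyl(methyl)carbamoyl in place of (ethoxycarbonyl)methyl gives a 6.7-fold higher number from compound 2 to compound 4 (0.83 log units; beyond the scatter). Both groups have the same number of heavy atoms, no ring and one double bond outside aromatic rings, so these counts do not separate them, and the step shows that a change of this kind can still move the number well beyond the scatter. Nothing available here explains the size of this step.

The compounds shown leave open how a methylcarbamoyl or a carboxylic acid on this carbon would read. They also leave open whether the higher number of compound 4 follows from the amide itself or from its ethyl and methyl groups.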